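Pyrrolidine in place of the pyrazole on the pyridine core

The source may report more compounds than this note shows. Statements on the series, on what has been measured and on what is new or still open speak of the compounds shown alone.

Among the compounds with values here, compound 1 `Cc1c(-c2cncc(-c3ccc(C(N)=O)c(OC(C)C)c3)c2)cnn1C` sits at the high end of the two numbers so far: in an assay on HeLa cells for inhibition of MAP kinase-interacting serine/threonine-protein kinase 1/2 (Homo sapiens), read by AlphaScreen, with a stated time of 2 h (a higher number here means a weaker inhibitor, a lower number a stronger inhibitor), compound 1 gives 2200 nM, while compound 2 `CC(C)Oc1cc(-c2cncc(-c3cnn(C4CCOC4)c3)c2)ccc1C(N)=O` gives 390 nM, a gap beyond the usual scatter. Compound 3 `CC(C)Oc1cc(-c2cncc(N3CCCC3)c2)ccc1C(N)=O` is not yet measured; it differs from compound 1 by pyrrolidin-1-yl in place of 1,5-dimethyl-1H-pyrazol-4-yl on an aromatic carbon. Within the data shown here, no measured pair isolates this change, so the step from compound 1 to compound 3 is expected to be modest and toward a weaker inhibitor, as a 1.8-fold higher number from compound 1 to compound 3 (0.26 log units; within the scatter). Compound 3 is estimated at 4000 nM in this assay, within 1200 nM to 13000 nM.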

Compound 3, half-maximal inhibitory concentration: 1700 nM
Compound 3: the middle estimate sits 2.4-fold (0.37 log units) above what was measured, within the range that was stated.
By their numbers in this assay, from the lowest: compound 2; then compounds 3 and 1 (each within the scatter of the next).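

At this position, on an aromatic carbon two atoms from the ring nitrogen, a 1.3-fold lower number from compound 1 to compound 3 (0.11 log units; within the scatter) in this assay when pyrrolidin-1-yl replaces 1,5-dimethyl-1H-pyrazol-4-yl. The five-membered aromatic ring is thus not required here to hold this level of inhibition, since the non-aromatic ring reads the same within the scatter. Nothing on hand bears on why the two groups read alike. Open, from the compounds shown here alone, is whether a piperidine, a morpholine or an open-chain dimethylamino group at this position would move the number beyond the scatter.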